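The source may report more compounds than this note shows. Statements on the series, on what has been measured and on what is new or still open speak of the compounds shown alone.

Compound 1 `CC(C)(C)C1=C(C(=O)O)N2C(=O)[C@H](CO)[C@@H]2O1` gives 2.4 h in an ADME assay, in phosphate buffer, at 28 degrees C, at pH 7.0; on this read-out lower numbers stand for a shorter-lived compound and higher numbers for a longer-lived compound.
Compound 2 `CC(C)(C)C1=C(C(=O)O)N2C(=O)[C@H]([C@H](O)c3ccccc3)[C@@H]2O1` gives 0.5 h in this assay.
Compound 3 `CC(C)(C)C1=C(C(=O)O)N2C(=O)[C@H]([C@H](O)CCc3ccncc3)[C@@H]2O1` gives 7.1 h in this assay.

Compound 2 holds the lowest of the three numbers in this assay: a 4.8-fold lower number from compound 1 to compound 2 (0.68 log units; beyond the scatter), and a 14-fold higher number from compound 2 to compound 3 (1.15 log units; beyond the scatter), both beyond the scatter, as is a 3.0-fold higher number from compound 1 to compound 3 (0.47 log units; beyond the scatter). Compound 4 `CC(C)(C)C1=C(C(=O)O)N2C(=O)[C@H]([C@@H](O)c3ccccc3)[C@H]2O1` is the diastereomer of compound 2: the two compounds have the same atoms and bonds and differ only in configuration as drawn: 2 of 3 stereo elements differ; a stereocentre at a saturated chain carbon is drawn S in compound 2 and R in compound 4; a stereocentre at a saturated ring carbon is drawn S in compound 2 and R in compound 4. Within the data shown here, each of the measured steps exchanges one group for another on the saturated chain carbon bound to an oxygen; none changes configuration while keeping the atoms the same, so no measured step bears on the step from compound 2 to compound 4 and no direction can be taken from them. The measured steps show that this read-out moves by modest to large amounts with changes at this position, which argues for a wide range rather than for a shift in either direction. From compound 2 the expected step is no change at the digits printed from compound 2 to compound 4 (within the scatter), within the scatter. The estimate for compound 4 in this assay is 0.5 h, with a range from 0.15 h to 1.8 h.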

Compound 4, half-life: 8.9 h
Compound 4: the middle estimate sits 18-fold (1.25 log units) below what was measured; measured number outside the range, above it.
By their numbers in this assay, from the lowest: compound 2; then compound 1; then compounds 3 and 4 (each within the scatter of the next).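

In this assay, a change of configuration alone moves the read-out by a large amount: an 18-fold higher number from compound 2 to compound 4 (1.25 log units; beyond the scatter), a step of the same large class as the group exchange a 14-fold higher number from compound 2 to compound 3 (1.15 log units; beyond the scatter). Phenyl on the saturated chain carbon therefore does not fix a short half-life by itself, as compound 2 and compound 4 both carry it. The step can be placed on stereochemistry rather than on any group because of one fact: the fact that compounds 2 and 4 differ only in the configuration as drawn.

On these data alone, the stereocentres at the saturated chain carbon and the saturated ring carbon change together in this pair, and which of them carries the step stays open. Also open, as far as these compounds go, is whether the same inversion gives a step of like size with 2-(pyridin-4-yl)ethyl or an aminoalkyl chain in place of phenyl.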